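Series notes: a butyl group on the phenyl of compound 2

This account rests on a few compounds, and the source may have more. Where it says the series, first, only, none or still open, it means among the compounds named here.

Measured so far:
compound 1, `CCCNC(=O)Nc1c(OCCCn2cnc(-c3ccccc3)c2)cccc1N(C)C`, 660 nM
compound 2, `CCCCCNC(=O)Nc1c(OCCCn2cnc(-c3ccccc3)c2)cccc1N(C)C`, 31 nM
compound 3, `CCCCCC(=O)Nc1c(OCCCn2cnc(-c3ccccc3)c2)cccc1N(C)C`, 200 nM

All three numbers come from an assay for inhibition of acyl-CoA:cholesterol acyltransferase (Oryctolagus cuniculus), using microsomes; on this read-out lower numbers stand for stronger inhibition and higher numbers for weaker inhibition. Compound 2 gives the lowest number of the three: compound 3 stands nearest, as seen in a 6.5-fold higher number from compound 2 to compound 3 (0.81 log units; beyond the scatter), and compound 1 furthest, as seen in a 21-fold lower number from compound 1 to compound 2 (1.33 log units; beyond the scatter). The step of a 3.3-fold lower number from compound 1 to compound 3 (0.52 log units; beyond the scatter) completes the set.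

The next compound, compound 4 `CCCCCNC(=O)Nc1c(OCCCn2cnc(-c3ccc(CCCC)cc3)c2)cccc1N(C)C`, keeps the whole of compound 2 and changes only the phenyl on the imidazole: butyl in place of hydrogen on an aromatic carbon.

Going by the values given here, none of the measured steps touches this ring; all three sit on the urea or amide side of the core. Among the compounds with values here, the one step that adds chain carbons, a 21-fold lower number from compound 1 to compound 2 (1.33 log units; beyond the scatter), is large and lowers the number, but it lies at a different place and cannot be carried over. Within the data shown here, with no step at the phenyl, the expectation for compound 4 is a number in the region of compound 2, with a wide range on either side. The expected step is a 1.2-fold lower number from compound 2 to compound 4 (0.09 log units; within the scatter). Compound 4 is estimated at 25 nM in this assay, with a range from 6 nM to 100 nM.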

Compound 4, half-maximal inhibitory concentration: 54 nM
The estimate for compound 4 lay 2.2-fold (0.33 log units) below the measured number, within the range that was stated.
By their numbers in this assay, from the lowest: compounds 2 and 4 (each within the scatter of the next); then compound 3; then compound 1.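

In this assay, going by these compounds alone, the change from phenyl to 4-butylphenyl gives a 1.7-fold higher number from compound 2 to compound 4 (0.24 log units; within the scatter), the first reading at this position, and compound 2 and compound 4 cannot be told apart. A butyl group of 4 heavy atoms can therefore sit on this aromatic carbon with no shift that stands clear of the scatter, whereas the chain extension in a 21-fold lower number from compound 1 to compound 2 (1.33 log units; beyond the scatter), made at a different place, moved the number well beyond it. No measurement at hand accounts for this result.

Still open, as far as these compounds go, is whether a methyl, a longer chain such as octyl, a carboxylic acid or a dimethylamino group on this same aromatic carbon would also leave the number within the scatter of compound 2, and whether butyl would read the same on the other carbons of the phenyl. Also open, from the compounds shown here alone, is whether the butyl group would behave in the same way on the side chain of compound 1 or of compound 3, which start from higher numbers than compound 2.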